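A few compounds are considered here, and "the series" means these few. Any claim that something is new, unique, unknown or untested is made for them only; others in the source may bear on it.

Compound 1 `O=C1/C(=C/c2ccccc2[N+](=O)[O-])CCc2ccccc21` and compound 2 `Cc1ccccc1/C=C1\CCc2ccccc2C1=O` share one core, while compound 3 `O=C1/C(=C/c2ccccc2[N+](=O)[O-])Cc2ccccc21` and the not yet measured compound 4 `Cc1ccccc1/C=C1\Cc2ccccc2C1=O` share another; the difference between the two cores is not broken down here. In a functional assay on P388 cells (Mus musculus) for inhibition (on this read-out higher numbers stand for weaker inhibition and lower numbers for stronger inhibition), compound 1 gives 12600 nM, and compound 2 gives 17700 nM. The change that separates them, (methyl in place of nitro on an aromatic carbon), made a step of a 1.4-fold higher number from compound 1 to compound 2 (0.15 log units; within the scatter). In this assay compound 3 gives 740 nM, the lowest of the three numbers, set apart from compound 1 and from compound 2 by gaps that lie beyond the scatter.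

Compound 4 carries against compound 3 the same change that compound 2 carries against compound 1: methyl in place of nitro on an aromatic carbon. Among the compounds with values here, the place of the change reads the same in both pairs, so the earlier step is the only guide available. Because compound 2 differs from compound 1 by a 1.4-fold higher number from compound 1 to compound 2 (0.15 log units; within the scatter), a step that lies within the scatter, a similarly small step is expected here, namely a 1.4-fold higher number from compound 3 to compound 4 (0.13 log units; within the scatter). This expectation rests on a single measured pair on a different core, so the true outcome for compound 4 could sit some way from it. On that basis compound 4 is estimated at 1000 nM in this assay, with a range from 350 nM to 3000 nM regarded as likely.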

Compound 4, half-maximal inhibitory concentration: 23900 nM
Compound 4: middle estimate off by 24-fold (1.38 log units), on the low side; measured number above the stated range.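

In this assay, methyl in place of nitro on an aromatic carbon gave a 32-fold higher number from compound 3 to compound 4 (1.51 log units; beyond the scatter), a large loss of inhibition on the core of compound 3, whereas the same change had made no step beyond the scatter on the core of compound 1. The two cores therefore do not share one value for this change, and a step measured on one of them could not be carried over to the other in this series: the same change on two cores in this assay, a 1.4-fold higher number (0.15 log units; within the scatter) from compound 1 to compound 2 and a 32-fold higher number (1.51 log units; beyond the scatter) from compound 3 to compound 4, 23-fold (1.36 log units) apart, beyond the scatter of two such steps. Within the data shown here, this shows that the size of the change depends on the core it sits on, but it rests on only two pairs, so it does not show which feature of the difference between the cores is responsible, nor how the change would behave on any further core.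

The compounds shown leave open whether other groups in place of nitro on the same aromatic carbon, such as an amine, a carboxylic acid or a methoxy group, would keep the inhibition of compound 3 or lose it as methyl does. They also leave open whether any such group would show the same dependence on the core in both pairs.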